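A few compounds are considered here, and "the series" means these few. Any claim that something is new, unique, unknown or untested is made for them only; others in the source may bear on it.

In a functional assay on HepG2 cells (Homo sapiens) for antiproliferative activity, read by MTT assay, with a stated time of 24 h (on this read-out lower numbers stand for stronger inhibition and higher numbers for weaker inhibition), compound 1 `COc1cc(OC)c(OC)cc1/C=C/C(=O)c1ccc(OC)c2c1OC(C)(C)C=C2` gives > 10000 nM, which is a limit and not a number. Compound 2 `COc1ccc(C(=O)/C=C/c2ccc(F)cc2)c2c1C=CC(C)(C)O2` gives > 10000 nM, also a limit, and so stands at the limit of > 10000 nM in this assay, at which 3 of the 3 values shown sit. Compound 3 `COc1ccc(C(=O)/C=C/c2cccc(F)c2)c2c1C=CC(C)(C)O2` gives > 10000 nM, again a limit. Compound 4 `COc1ccc(C(=O)/C=C/c2ccc(N(C)C)cc2)c2c1C=CC(C)(C)O2` has dimethylamino in place of fluoro on an aromatic carbon of compound 2: dimethylamino in place of fluoro on an aromatic carbon. Within the data shown here, the one measured step that bears on this change, a step that the two limits leave unreadable from compound 2 to compound 3, moves the fluoro group and offers no usable size or direction. No step beyond the usual scatter is therefore expected, and the estimated change is a step that the limit leaves unreadable from compound 2 to compound 4. For compound 4, the expected value is 12000 nM, within an estimated range of 4000 nM to 40000 nM.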

Compound 4, half-maximal inhibitory concentration: 730 nM
The estimate for compound 4 lay 16-fold (1.22 log units) above the measured number; the whole stated range lies above it.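

In this assay, among these compounds, compound 4 is the first compound here to move off the limit: the limit of > 10000 nM in this assay, at which 3 of the 4 values shown sit. Dimethylamino in place of fluoro gives an at least 13-fold lower number from compound 2 to compound 4 (1.13 log units; beyond the scatter), so the group on this aromatic carbon can change the read-out strongly. 4-(Dimethylamino)phenyl in place of 3-fluorophenyl gives an at least 13-fold lower number from compound 3 to compound 4 (1.13 log units; beyond the scatter), although that pair differs in both the group and its place.

The steps among the compounds at the limit cannot be read, so moving the fluoro group has no measurable effect to report. From the compounds shown here alone, it remains open whether another amine in this place, such as a plain amino group or pyrrolidine, would keep the lower number.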